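The source may report more compounds than this note shows. Statements on the series, on what has been measured and on what is new or still open speak of the compounds shown alone.

Of the compounds shown here, three have been measured in a functional assay on HCT-116 cells (Homo sapiens) for inhibition, read by MTT assay, with a stated time of 72 h; on this read-out higher numbers stand for weaker inhibition of growth and lower numbers for stronger inhibition of growth. For the measured compounds named here, compound 1 `COC1=C(C)C(=O)C(CCCCCCCCCCn2cc(C[C@H](O)COCCOC[C@@H](O)Cc3ccc(-c4ccccc4)cc3)nn2)=C(C)C1=O` gives 4000 nM, and compound 2 `COC1=C(OC)C(=O)C(CCCCCCCCCCn2cc(C[C@H](O)COCCOC[C@@H](O)Cc3ccc(-c4ccccc4)cc3)nn2)=C(C)C1=O` gives 600 nM; the one step between them, a 6.7-fold lower number from compound 1 to compound 2 (0.82 log units; beyond the scatter), is the only measured step in this set. Compound 3 `O=C1COc2ccc(-n3cc(C[C@H](O)COCCOC[C@@H](O)Cc4ccc(-c5ccccc5)cc4)nn3)cc2N1` gives 42500 nM, the highest of the three numbers and so the weakest growth inhibition measured, beyond the scatter from both of the others. Compound 4 `O[C@H](COCCOC[C@@H](O)Cc1cn(-c2ccc3[nH]ccc3c2)nn1)Cc1ccc(-c2ccccc2)cc1` is not yet measured and differs from compound 3 in one place: a group of 9 heavy atoms (8 carbon, 1 nitrogen; one five-membered aromatic ring with 1 hetero atom, one six-membered aromatic ring of carbon only) in place of a group of 11 heavy atoms (8 carbon, 1 nitrogen, 2 oxygen; one six-membered non-aromatic ring with 2 hetero atoms, one six-membered aromatic ring of carbon only), on an aromatic nitrogen. Going by the values given here, the single measured step concerns a different part of the shared structure and does not bear on this change; nothing measured shows how a swap of the group on the aromatic nitrogen moves the number. With no guidance, the expected step is a 1.4-fold lower number from compound 3 to compound 4 (0.15 log units; within the scatter), staying within the scatter, while the range is kept wide to reflect that uncertainty. Compound 4 is therefore estimated at 30000 nM, within 8000 nM to 100000 nM.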

Compound 4, concentration for 50% growth inhibition: 15500 nM
Compound 4: middle estimate off by 1.9-fold (0.29 log units), on the high side; the range from low to high includes it.
By their numbers in this assay, from the lowest: compound 2; then compound 1; then compound 4; then compound 3.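

Within this assay the group on the aromatic nitrogen can move the number: 1H-indol-5-yl in place of the group of 11 heavy atoms gives a 2.7-fold lower number from compound 3 to compound 4 (0.44 log units; beyond the scatter) and so provides the first measured step at this position. The swap alters several features at once, since the non-aromatic ring and both oxygens leave, the five-membered aromatic ring enters, and one hydrogen-bond donor is present on each side, so this single step cannot tie the change to any one of them. Nothing available explains why the number moves.

On these data alone, it remains open whether a plain phenyl or a quinolinyl group on the same nitrogen would lower the number further or raise it. Also open, as far as these compounds go, is whether an N-methylindol-5-yl group would keep this step.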